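The compounds below may be only part of what the source reports. "The series", "measured", "known", "first", "only" and "open" are said of these compounds alone.

Three measured compounds anchor this account. Compound 1 `FC(F)(F)c1ccc2nc(-c3cccc(-c4nc5ccc(C(F)(F)F)cc5[nH]4)c3)[nH]c2c1` gives 8900 nM in a functional assay on A549 cells (Homo sapiens) for cytotoxicity, read by MTT assay, with a stated time of 48 h; on this read-out higher numbers stand for weaker inhibition and lower numbers for stronger inhibition. Compound 2 `Fc1ccc2nc(-c3cccc(-c4nc5ccc(F)cc5[nH]4)c3)[nH]c2c1` returns only a limit of the assay, > 100000 nM. Compound 3 `COc1cc(-c2nc3ccc([N+](=O)[O-])cc3[nH]2)cc(-c2nc3ccc([N+](=O)[O-])cc3[nH]2)c1` gives 18500 nM in this assay, the highest of the two numbers shown; its nearest neighbour is compound 1, whose number is lower by a gap beyond the usual scatter. The unmeasured compound 4 `O=[N+]([O-])c1cc(-c2nc3ccc([N+](=O)[O-])cc3[nH]2)cc(-c2nc3ccc([N+](=O)[O-])cc3[nH]2)c1` differs from compound 3 in one place: nitro in place of methoxy on an aromatic carbon. Within the data shown here, no pair of measured compounds differing in a single place is available, so the size of this step is an expectation only; she expects it to stay within the scatter, in no firm direction. Compound 4 is therefore estimated at 15000 nM, with a likely range from 5000 nM to 50000 nM, a step of a 1.2-fold lower number from compound 3 to compound 4 (0.09 log units; within the scatter).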

Compound 4, half-maximal inhibitory concentration: 13600 nM
The estimate for compound 4 lay 1.1-fold (0.04 log units) above the measured number; the range from low to high includes it.
By their numbers in this assay, from the lowest: compounds 1, 4 and 3 (each within the scatter of the next, the first and the last beyond it). At a limit, above all of these: compound 2.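

Nitro in place of methoxy on an aromatic carbon, meta to two large groups, gives a 1.4-fold lower number from compound 3 to compound 4 (0.13 log units; within the scatter) in this assay, the first step here between compounds that differ in one place. At this position, then, the two groups cannot be told apart in this read-out. Nothing measured here bears on why they read alike.

On these data alone, whether an amine, a carboxylic acid or a longer chain at this position would read the same stays open. So does whether this exchange would behave alike on the core of compound 1.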